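The source may report more compounds than this note shows. Statements on the series, on what has been measured and on what is new or still open speak of the compounds shown alone.

Compound 1 `COCCN1C(=O)CNc2ncc(-c3ccc(C(C)(C)O)nc3)nc21`: 9960 ng.h/mL
Compound 2 `CC(C)(O)c1ccc(-c2cnc3c(n2)N(CC2CCCCC2)CC(=O)N3)cn1`: "not determined" (no result reported)
Compound 3 `CO[C@H]1CC[C@@H](N2CC(=O)Nc3ncc(-c4ccc(C(C)(C)O)nc4)nc32)CC1`: 10600 ng.h/mL

In an ADME assay on the whole organism for pharmacokinetics, with Rattus norvegicus as the target, at a dose of 5 mg/kg by the oral route (a lower number here means less compound in the circulation, a higher number more compound in the circulation at the dose given), compound 1 gives 9960 ng.h/mL, within the scatter of compound 3 at 10600 ng.h/mL. Compound 2 offers no number for comparison. Compound 4 `CO[C@H]1CC[C@H](N2C(=O)CNc3ncc(-c4ccc(C(C)(C)O)nc4)nc32)CC1` is not yet measured. It carries 4-methoxycyclohexyl in place of 2-methoxyethyl on an amide-type nitrogen in a ring of the core of compound 1: 4-methoxycyclohexyl in place of 2-methoxyethyl on an amide-type nitrogen in a ring. Within the data shown here, no measured step shows this change directly. Compound 3, which also bears a 4-methoxycyclohexyl group, gives 10600 ng.h/mL, so no large loss is expected. The expected change is a 1.4-fold lower number from compound 1 to compound 4 (0.15 log units; within the scatter), a small fall that may not exceed the scatter. The estimate for compound 4 is 7000 ng.h/mL, with an expected range of 2500 ng.h/mL to 18000 ng.h/mL.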

Compound 4, area under the concentration-time curve: 10300 ng.h/mL
Compound 4: middle estimate off by 1.5-fold (0.17 log units), on the low side, within the range that was stated.
By their numbers in this assay, from the lowest: compounds 1, 4 and 3 (each within the scatter of the next).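

At the amide-type nitrogen in a ring, 4-methoxycyclohexyl in place of 2-methoxyethyl gives a 1.0-fold higher number from compound 1 to compound 4 (0.01 log units; within the scatter) in this assay. Among these compounds, this is the first direct reading of this change: a group with a six-membered carbon ring and 2 defined stereocentres can stand here with a step that stays within the scatter. No measured data on hand explain this result.

Still open, on these data alone, is whether an amine or a carboxylic acid on this nitrogen would give a step beyond the scatter. A longer ether chain at this position also remains untested by the compounds shown.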